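A Larger Branched Amine on a Scaffold Without a Number

The source may hold more compounds than are shown below. What is called first, only, known or untested is meant among the compounds shown, and "the series" means these compounds.

Compound 3 `Cc1ncc(CO)c2c(Nc3ccccn3)c(NC(C)(C)C)oc12` carries a (tert-butyl)amino group, and in a functional assay on HEK293 cells for agonist activity at Toll-like receptor 8 (Homo sapiens), read by reporter gene assay (a higher number here means that more compound is needed for the effect, a lower number that less compound is needed), compound 3 is recorded as "not active" (no number reported), so no single number places it on the scale. Two other compounds share its core. Compound 1 `CCOC(=O)CNc1oc2c(C)ncc(CO)c2c1Nc1ccccn1` is likewise recorded as "not active" (no number reported) in this assay. Compound 2 `Cc1ncc(CO)c2c(Nc3ccccn3)c(N[C@@H](C)c3ccccc3)oc12`, with a 1-phenylethylamino group, reaches 4270 nM in this assay, the only numbered result among the three. Compound 4 `Cc1ncc(CO)c2c(Nc3ccccn3)c(NC(C)(C)CC(C)(C)C)oc12` has not yet been measured. It differs from compound 3 by tert-butyl in place of hydrogen on a saturated chain carbon, two bonds along the chain from a nitrogen on an aromatic ring, so the (tert-butyl)amino becomes a (1,1,3,3-tetramethylbutyl)amino. Going by the values given here, no measured pair shows what such an extension does on this core, and compound 3 itself gives no number to build on, so the size and direction of the step cannot be taken from the data; the only anchor is the value of compound 2. Compound 4 is therefore expected to show modest activity or none, with its estimate in this assay being 9000 nM within a range from 2000 nM to 40000 nM.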

Compound 4, half-maximal effective concentration: "not active" (no number reported)
Nothing numeric was reported for compound 4; no gap can be computed for the estimate.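

In this assay compound 3 gives "not active" (no number reported) and compound 4 gives "not active" (no number reported), so no step can be read between them, and nothing at hand explains this result. On these data alone, what the (1,1,3,3-tetramethylbutyl)amino group does relative to the (tert-butyl)amino group on the shared core stays open.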